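A Halogen Swap on Compound 1 and Its Expected Effect

A few compounds are considered here, and "the series" means these few. Any claim that something is new, unique, unknown or untested is made for them only; others in the source may bear on it.

Compound 1 `O=C1C(Nc2ccc(Br)cc2)=CC(=O)c2c1nc1n2[C@H]2OC[C@@H](O)[C@H]2OC1`: 1980 nM
Compound 2 `O=C1C=C(Nc2ccc(Br)cc2)C(=O)c2c1nc1n2[C@H]2OC[C@@H](O)[C@H]2OC1`: 2850 nM

In a functional assay on ECa-109 cells for inhibition, with ECa-109 cell line (Homo sapiens) as the target, read by sulforhodamine B assay (on this read-out higher numbers stand for weaker inhibition and lower numbers for stronger inhibition), compound 1 gives 1980 nM, the lowest of the two numbers measured. Compound 2 gives 2850 nM, a gap that stays within the usual scatter, so the two cannot be ranked. Compound 3 `O=C1C(Nc2cccc(F)c2)=CC(=O)c2c1nc1n2[C@H]2OC[C@@H](O)[C@H]2OC1` has not been measured yet. It differs from compound 1 by 3-fluorophenyl in place of 4-bromophenyl on an amine nitrogen. For the measured compounds named here, no measured pair shows this change, so its effect is unknown; a modest shift in this assay, most likely toward a somewhat higher number, is expected, as a step of a 1.5-fold higher number from compound 1 to compound 3 (0.18 log units; within the scatter). For compound 3 the estimated value is 3000 nM, in a range from 1000 nM to 9000 nM.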

Compound 3, half-maximal inhibitory concentration: 2370 nM
Compound 3: middle estimate off by 1.3-fold (0.10 log units), on the high side; the measured number falls inside the stated range.
By their numbers in this assay, from the lowest: compounds 1, 3 and 2 (each within the scatter of the next).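

Putting 3-fluorophenyl in place of 4-bromophenyl on the amine nitrogen gives a 1.2-fold higher number from compound 1 to compound 3 (0.08 log units; within the scatter) in this assay. This shows that, at this position, a phenyl ring carrying either halogen gives numbers that cannot be told apart, so this change alone does not separate the two compounds. Nothing available here explains this result.

Still open, as far as these compounds go, is what a benzyl group or a plain alkyl chain would do in place of the phenyl ring on that nitrogen. Also open, from the compounds shown here alone, is whether a methoxy group on the phenyl ring would give a step beyond the scatter.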